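The source may report more compounds than this note shows. Statements on the series, on what has been measured and on what is new or still open speak of the compounds shown alone.

The series shares one core, varied at a single aromatic carbon. Compound 1 `COc1cc(-n2ncnc2-c2ccccc2)cc(OC)c1OC` carries hydrogen at that position. In a functional assay on A549 cells (Homo sapiens) for antiproliferative activity, read by MTT assay, with a stated time of 72 h (a lower number here means a stronger inhibitor, a higher number a weaker inhibitor), compound 1 gives > 10000 nM, which is a limit of the assay rather than a number. Compound 2 `COc1cc(-n2ncnc2-c2ccc(Cl)cc2)cc(OC)c1OC` carries chloro there. In this assay compound 2 gives > 10000 nM, again a limit and not a number. Compound 3 `CCOc1ccc(-c2ncnn2-c2cc(OC)c(OC)c(OC)c2)cc1` carries ethoxy. In this assay, going by the values given here, compound 3 gives 100 nM, the one number among the three results, the other two sitting at the limit of > 10000 nM in this assay, at which 2 of the 3 values shown sit. The steps that reach compound 3 are large: an at least 100-fold lower number from compound 1 to compound 3 (2.00 log units; beyond the scatter) and an at least 100-fold lower number from compound 2 to compound 3 (2.00 log units; beyond the scatter). The step between the two inactive members cannot be sized, a step that the two limits leave unreadable from compound 1 to compound 2.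

Compound 4 `COc1cc(-n2ncnc2-c2ccc(SC)cc2)cc(OC)c1OC` differs from compound 3 in one place: methylsulfanyl in place of ethoxy on an aromatic carbon. Both groups stand on the same aromatic carbon of the six-membered aromatic ring of carbon only, para to a large group. Among the compounds with values here, no measured step involves methylsulfanyl, so the change is judged only from the fact that ethoxy in compound 3 gave 100 nM, a number where hydrogen and chloro gave none. A modest step of a 3.0-fold higher number from compound 3 to compound 4 (0.48 log units; beyond the scatter) is expected in this assay. The estimate for compound 4 is 300 nM, with a range from 60 nM to 3000 nM.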

Compound 4, half-maximal inhibitory concentration: 800 nM
Compound 4: middle estimate off by 2.7-fold (0.43 log units), on the low side; the range from low to high includes it.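

Ethoxy is not alone at this aromatic carbon in giving a readable number in this assay: methylsulfanyl does so too, with an at least 12-fold lower number from compound 1 to compound 4 (1.09 log units; beyond the scatter) when it replaces hydrogen and an at least 12-fold lower number from compound 2 to compound 4 (1.09 log units; beyond the scatter) when it replaces chloro. The two groups are still not equal here, with an 8.0-fold higher number from compound 3 to compound 4 (0.90 log units; beyond the scatter), so ethoxy keeps the lower number of the two, although neither group brings a ring or a net charge. Compound 1 with hydrogen and compound 2 with chloro remain limits rather than numbers, so the steps from them give only a lower bound on the gain: the limit of > 10000 nM in this assay, at which 2 of the 4 values shown sit.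

The compounds shown leave open whether methoxy or a longer chain such as propoxy at this carbon would give a lower or a higher number than ethoxy, and so whether chain length matters at all. They also leave open how an amine or a carboxylic acid would fare there, and whether the ethylsulfanyl counterpart of ethoxy would close the gap between the oxygen-linked and sulfur-linked groups.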